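The source may hold more compounds than are shown below. What is called first, only, known or untested is meant among the compounds shown, and "the series" means these compounds.

Three compounds share one core and were tested in a functional assay on the whole organism (strain Swiss albino) for inhibition, with Mus musculus as the target, in the writhing test, with a stated time of 30 min, at a dose of 20 mg/kg by the oral route; on this read-out higher numbers stand for a stronger effect at the one dose given and lower numbers for a weaker effect. Compound 1, `Cc1c(C=O)cc(-c2ccc(S(C)(=O)=O)cc2)n1-c1cccc(F)c1`, gives 44% in this assay. Compound 2, `Cc1c(C=O)cc(-c2ccc(S(C)(=O)=O)cc2)n1-c1ccccc1`, gives 32%. Compound 3, `Cc1c(/C=N\O)cc(-c2ccc(S(C)(=O)=O)cc2)n1-c1ccc(F)cc1`, gives 41%; its number sits among those of compounds 1 and 2, within the usual scatter of both, so no order among the three can be read from them.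

The unmeasured compound 4 is `Cc1c(/C=N\O)cc(-c2ccc(S(C)(=O)=O)cc2)n1-c1ccccc1`. It differs from compound 3 by hydrogen in place of fluoro on an aromatic carbon. One measured step shows the same kind of change, fluoro replaced by hydrogen on the aromatic ring, though in compounds that carry a different group on the core and a fluoro at a different spot: a number 12 percentage points lower from compound 1 to compound 2 (beyond the scatter). Among the compounds with values here, that step was modest but beyond the scatter, and it is the only guide available. A step of similar size and the same direction is therefore expected in this assay. The expected step is a number 10 percentage points lower from compound 3 to compound 4 (within the scatter). Compound 4 is estimated to give 31%, within a range from 18% to 44%.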

Compound 4, a percentage reported as inhibition, in the whole organism at one dose (the size of the read-out at that dose, not a potency): 53%
Beside the measured number, compound 4's estimate is 22 percentage points below it; the whole stated range lies below it.
By their numbers in this assay, from the lowest: compounds 2, 3, 1 and 4 (each within the scatter of the next, the first and the last beyond it).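

The fluoro on this ring has no single effect that carries from one compound pair to the next, since in this assay its replacement by hydrogen gives a number 12 percentage points higher from compound 3 to compound 4 (beyond the scatter), the opposite direction to the earlier pair: the same change on two cores in this assay, a number 12 percentage points lower (beyond the scatter) from compound 1 to compound 2 and a number 12 percentage points higher (beyond the scatter) from compound 3 to compound 4, 24 percentage points apart, beyond the scatter of two such steps. The two pairs differ both in the group on the core and in where the fluoro sits, so the effect of this change holds only for the setting in which it was read. With phenyl on both compounds, the oxime in place of the aldehyde gives a number 21 percentage points higher from compound 2 to compound 4 (beyond the scatter), the largest step seen so far.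

As far as these compounds go, whether the reversal follows the core group or the fluoro's place remains open. Also open, from the compounds shown here alone, is what a chlorine atom in place of that fluoro, or a carboxylic acid in place of the aldehyde, would give.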